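Benzyl-ring chloro substitution in a dopamine transporter series

This account rests on a few compounds, and the source may have more. Where it says the series, first, only, none or still open, it means among the compounds named here.

Measured so far, in an assay on isolated protein for binding affinity to sodium-dependent dopamine transporter (Rattus norvegicus); on this read-out lower numbers stand for stronger inhibition and higher numbers for weaker inhibition:
compound 1 `COc1cccc(CN2CCC(CCOC(c3ccc(F)cc3)c3ccc(F)cc3)CC2)c1`: 13.3 nM
compound 2 `Fc1ccc(C(OCCC2CCN(Cc3ccccc3)CC2)c2ccc(F)cc2)cc1`: 9.9 nM

In this assay compound 2 gives 9.9 nM, the lowest of the two numbers, though its gap to compound 1 is within the scatter: a 1.3-fold lower number from compound 1 to compound 2 (0.13 log units; within the scatter). Compound 3 `Fc1ccc(C(OCCC2CCN(Cc3ccc(Cl)cc3)CC2)c2ccc(F)cc2)cc1` is not yet measured; it differs from compound 2 by chloro in place of hydrogen on an aromatic carbon, para to a large group. Among the measured compounds shown here, the single measured step, a 1.3-fold lower number from compound 1 to compound 2 (0.13 log units; within the scatter), lay within the scatter and does not involve chloro, so it gives little guidance. A small step, if any, is expected: a 1.4-fold lower number from compound 2 to compound 3 (0.15 log units; within the scatter). Compound 3 is estimated at 7 nM, within 3 nM to 20 nM.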

Compound 3, inhibition constant: 1.2 nM
Compound 3: the middle estimate sits 5.8-fold (0.77 log units) above what was measured, outside the stated range (below it).
By their numbers in this assay, from the lowest: compound 3; then compounds 2 and 1 (each within the scatter of the next).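

In this assay, 4-chlorobenzyl in place of benzyl gives an 8.3-fold lower number from compound 2 to compound 3 (0.92 log units; beyond the scatter) and thus shows that this ring carbon, para to a large group, responds to chloro, a sensitivity the step from compound 1 to compound 2 did not reveal. Set against the 3-methoxyphenyl of compound 1, the 4-chlorophenyl gives an 11-fold lower number from compound 1 to compound 3 (1.04 log units; beyond the scatter) and so extends the same picture, though this step exchanges one substituted group for another. No measurement on hand accounts for either step. The compounds shown leave open whether bromo, trifluoromethyl or a nitrile at this carbon would behave like chloro. Going by these compounds, whether chloro would have the same effect elsewhere on this ring also stays open.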